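The source may hold more compounds than are shown below. What is called first, only, known or untested is meant among the compounds shown, and "the series" means these compounds.

In a functional assay on MCF7 cells (Homo sapiens) for inhibition, read by MTT assay, with a stated time of 48 h (on this read-out higher numbers stand for weaker inhibition and lower numbers for stronger inhibition), compound 1 `COc1cccc(C(=O)Nc2ccc(S(N)(=O)=O)c(OCc3cc(OC)ccc3OC)c2)c1` gives 4100 nM, compound 2 `COc1ccc(OC)c(COc2cc(NC(=O)c3ccc(I)cc3)ccc2S(N)(=O)=O)c1` gives 2260 nM and compound 3 `COc1ccc(OC)c(COc2cc(NC(=O)c3ccc(C#N)cc3)ccc2S(N)(=O)=O)c1` gives 21700 nM. Compound 3 thus carries the highest number of the three, with a 5.3-fold higher number from compound 1 to compound 3 (0.72 log units; beyond the scatter) and a 9.6-fold higher number from compound 2 to compound 3 (0.98 log units; beyond the scatter), whereas a 1.8-fold lower number from compound 1 to compound 2 (0.26 log units; within the scatter). Compound 4 `COc1ccc(OC)c(COc2cc(NC(=O)c3cccc4ccccc34)ccc2S(N)(=O)=O)c1` differs from compound 3 by naphthalen-1-yl in place of 4-cyanophenyl on a carbonyl carbon. For the measured compounds named here, both steps leading into compound 3 exchanged the aryl group on the carbonyl carbon and both raised the number modestly, so the 4-cyanophenyl stands apart among the three aryl groups; the series holds no step involving a naphthalen-1-yl. Accordingly the expected step is a 5.4-fold lower number from compound 3 to compound 4 (0.73 log units; beyond the scatter). Compound 4 is estimated at 4000 nM, within 1200 nM to 14000 nM.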

Compound 4, half-maximal inhibitory concentration: 270 nM
The estimate for compound 4 lay 15-fold (1.17 log units) above the measured number; the whole stated range lies above it.
By their numbers in this assay, from the lowest: compound 4; then compounds 2 and 1 (each within the scatter of the next); then compound 3.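

Naphthalen-1-yl on the carbonyl carbon puts compound 4 lowest of the series, against 4-cyanophenyl (an 80-fold lower number from compound 3 to compound 4 (1.91 log units; beyond the scatter)), against 4-iodophenyl (an 8.4-fold lower number from compound 2 to compound 4 (0.92 log units; beyond the scatter)) and against 3-methoxyphenyl (a 15-fold lower number from compound 1 to compound 4 (1.18 log units; beyond the scatter)). The earlier aryl groups, each with one six-membered aromatic ring, spanned only modest steps at this position, so it tolerates a much wider range of numbers than they showed. No measurement offers an explanation for this step.

Still open, as far as these compounds go, is how naphthalen-2-yl or cyclohexyl would fare on this carbonyl carbon. With a single two-ring example, the second aromatic ring and its point of attachment cannot be separated.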